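The source may report more compounds than this note shows. Statements on the series, on what has been measured and on what is new or still open speak of the compounds shown alone.

Measured so far in a functional assay on CCRF-CEM cells (Homo sapiens) for antiproliferative activity, read by MTT assay, with a stated time of 24 h, tested at 50 uM; on this read-out lower numbers stand for a stronger effect and higher numbers for a weaker effect at the one concentration tested:
Compound 1, `OC(CCn1nc2c(Br)c(Br)c(Br)c(Br)c2n1)c1ccccc1`, gives 66%
Compound 2, `OC(CCn1nc2c(Br)c(Br)c(Br)c(Br)c2n1)c1ccc(Br)cc1`, gives 58%

Compound 2 stands at the lower of these two numbers, and the step of a number 8 percentage points lower from compound 1 to compound 2 (within the scatter) is within the scatter, so the two compounds cannot be ranked. Compound 3, `OC(CCn1nc2c(Br)c(Br)c(Br)c(Br)c2n1)c1ccc(Cl)cc1`, has not yet been measured. It differs from compound 2 only at the same aromatic carbon: chloro in place of bromo on an aromatic carbon. Within the data shown here, the one measured step bears on this change, since it swapped a group at that very carbon, and it stayed within the scatter. A step of similar small size, in no particular direction, is therefore expected in this assay . Compound 3 is estimated at 60%, with a range from 48% to 72%, meaning an expected step of a number 2 percentage points higher from compound 2 to compound 3 (within the scatter).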

Compound 3, a percentage reported as activity, at one concentration (the size of the read-out at that concentration, not a potency): 56%
Beside the measured number, compound 3's estimate is 4 percentage points above it; measured number inside the range.
By their numbers in this assay, from the lowest: compounds 3, 2 and 1 (each within the scatter of the next).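

In this assay, swapping one halogen for the other at this aromatic carbon gives a number 2 percentage points lower from compound 2 to compound 3 (within the scatter), so these two halogens cannot be told apart here. Chloro in place of hydrogen gives a number 10 percentage points lower from compound 1 to compound 3 (within the scatter), so chloro, like bromo, gives no step that can be separated from the scatter. Nothing measured here bears on the reason for these small steps.

From the compounds shown here alone, it remains open whether a different kind of group at this carbon, such as an amine or a carboxylic acid, would give a step beyond the scatter. Changes to the chain or the shared core also remain open.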